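A few compounds are considered here, and "the series" means these few. Any claim that something is new, unique, unknown or untested is made for them only; others in the source may bear on it.

Measured in a functional assay on WRL68 cells (Homo sapiens) for cytotoxicity, read by MTT assay, with stated times of 6 h and 48 h; on this read-out lower numbers stand for stronger inhibition and higher numbers for weaker inhibition:
- compound 1 `COc1ccc(OC)c(C(=O)/C=C/c2cc(Br)c(Br)n2C)c1`: 3270 nM
- compound 2 `Cn1c(/C=C/C(=O)c2cccc(O)c2)cc(Br)c1Br`: >= 100000 nM
- compound 3 `COc1ccc(C(=O)/C=C/c2cc(Br)c(Br)[nH]2)c(OC)c1`: 9220 nM

Compound 2 reads >= 100000 nM, which is a limit of the assay and not a number. That leaves two true numbers. Compound 1 holds the lower of them at 3270 nM, and the gap up to compound 3 lies beyond the scatter.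

Compound 4 `COc1ccc(OC)c(C(=O)/C=C/c2cc(Br)c(Br)[nH]2)c1` is not yet measured. It differs from compound 1 by hydrogen in place of methyl on an aromatic nitrogen, with hydrogen in place of methyl on an aromatic nitrogen.

Among the compounds with values here, no measured pair isolates this change, so the expectation rests on thin ground. Within the data shown here, the only measured compound with hydrogen on that nitrogen is compound 3, at 9220 nM, and it differs elsewhere too. A small rise in the number is therefore expected in this assay, possibly not beyond the scatter. The estimate is a 1.8-fold higher number from compound 1 to compound 4 (0.26 log units; within the scatter).

For compound 4 the estimated value is 6000 nM, with an expected range of 2500 nM to 20000 nM.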

Compound 4, half-maximal inhibitory concentration: 12300 nM
The estimate for compound 4 lay 2.1-fold (0.31 log units) below the measured number; the measured number falls inside the stated range.
By their numbers in this assay, from the lowest: compound 1; then compounds 3 and 4 (each within the scatter of the next). At a limit, above all of these: compound 2.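

In this assay the methyl on the aromatic nitrogen of the five-membered ring matters: hydrogen in its place gives a 3.8-fold higher number from compound 1 to compound 4 (0.58 log units; beyond the scatter). Within the data shown here, the earlier compounds held no pair differing only at this nitrogen, so this is the first isolated reading of the change, and it rests on this single pair. Nothing measured in this set gives a reason for the step.

On these data alone, compound 2 also carries methyl on this nitrogen, but its >= 100000 nM is a limit of the assay and not a number, so whether the step holds in that compound stays open. Also open, as far as these compounds go, is how this nitrogen would read with an ethyl group, a longer chain or a chain ending in an amine in place of methyl.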